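The compounds below may be only part of what the source reports. "The series", "measured", "known", "first", "only" and "open" are said of these compounds alone.

Compound 1 `COc1cc([C@](O)(CCN(C)C)[C@@H](c2cc3cc(Br)ccc3nc2OC)c2cccc(OC)c2F)cc(OC(C)C)n1`, compound 2 `COc1cc([C@](O)(CCN(C)C)[C@@H](c2cc3cc(Br)ccc3nc2OC)c2cccc(OC)c2F)cc(OC(F)F)n1` and compound 3 `COc1cc([C@](O)(CCN(C)C)[C@@H](c2cc3cc(Br)ccc3nc2OC)c2cccc(OC)c2F)cc(SC)n1` share one core and differ in a single group on an aromatic carbon. In an ADME assay on the whole organism (Mus musculus, strain CD-1) for pharmacokinetics, at a dose of 10 mg/kg by the oral route (a higher number here means that a larger share of the oral dose reaches the circulation, a lower number that a smaller share of the oral dose reaches the circulation), compound 1 gives 43%, compound 2 gives 83% and compound 3 gives 31%, the lowest of the three. Changing that one group produced a number 40 percentage points higher from compound 1 to compound 2 (beyond the scatter), along with a number 12 percentage points lower from compound 1 to compound 3 (beyond the scatter) and a number 52 percentage points lower from compound 2 to compound 3 (beyond the scatter). Compound 4 `COc1cc([C@](O)(CCN(C)C)[C@@H](c2cc3cc(C#N)ccc3nc2OC)c2cccc(OC)c2F)cc(SC)n1` keeps the methylsulfanyl group of compound 3 and changes a different place: cyano in place of bromo on an aromatic carbon. Among the measured compounds shown here, none of the measured steps touches the bromo place, so the data give no direct guide to the direction of this change. For the measured compounds named here, they show only that single changes can be large or modest in this assay. No shift beyond the scatter is therefore expected, and the estimated step is a number 2 percentage points higher from compound 3 to compound 4 (within the scatter). For compound 4 the expected value is 33%, with an estimated range of 14% to 55%.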

Compound 4, oral bioavailability: 28%
Compound 4: middle estimate off by 5 percentage points, on the high side, within the range that was stated.
By their numbers in this assay, from the lowest: compounds 4 and 3 (each within the scatter of the next); then compound 1; then compound 2.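

This first view of the bromo place shows that cyano in place of bromo on an aromatic carbon, with the methylsulfanyl group kept, gives a number 3 percentage points lower from compound 3 to compound 4 (within the scatter) in this assay. Here, entry of a group with one more heavy atom and a hydrogen-bond acceptor leaves the share of the oral dose reaching the circulation within the scatter, unlike the other varied place, where one change gave a number 52 percentage points lower from compound 2 to compound 3 (beyond the scatter). Nothing measured here explains this result.

The compounds shown pair cyano only with methylsulfanyl, so it remains open whether the same swap would behave alike with the difluoromethoxy group of compound 2 or the isopropoxy group of compound 1. From the compounds shown here alone, how a chloro group, an amine or a carboxylic acid at the bromo place would read also remains open.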